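The source may report more compounds than this note shows. Statements on the series, on what has been measured and on what is new or still open speak of the compounds shown alone.

Working notes on the series. Compound 1 `Cn1ccc2c(Oc3ccc(NC(=O)c4cc5cccnc5n(-c5ccc(F)cc5)c4=O)cc3)ccnc21` carries a 4-fluorophenyl on the shared core; in a functional assay on NCI-H460 cells (Homo sapiens) for antiproliferative activity, read by MTT assay, with a stated time of 72 h (on this read-out lower numbers stand for stronger inhibition and higher numbers for weaker inhibition), compound 1 gives 260 nM. Compound 2 `Cn1ccc2c(Oc3ccc(NC(=O)c4cc5cccnc5n(-c5ccc(Br)cc5)c4=O)cc3)ccnc21` carries a 4-bromophenyl in the same place, but in this assay compound 2 gives "not determined" (no result reported): no single number, so it stands nowhere on the numbers shown, and nothing can be said of its gap to compound 1.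

Compound 3 `COc1ccc(-n2c(=O)c(C(=O)Nc3ccc(Oc4ccnc5c4ccn5C)cc3)cc3cccnc32)cc1` is the next member, to be measured in this assay. The change from compound 2 to compound 3 is methoxy in place of bromo on an aromatic carbon. Among the compounds with values here, no measured step exists for this change, and compound 2 gives no reference value. Within the data shown here, from compound 1, the only number in hand, no step beyond the scatter in this assay is expected in either direction for a change of this kind. Compound 3 is therefore estimated at 300 nM in this assay, with a range from 100 nM to 1000 nM.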

Compound 3, half-maximal inhibitory concentration: 1920 nM
Compound 3: the middle estimate sits 6.4-fold (0.81 log units) below what was measured; measured number above the stated range.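

In this assay this place on the aromatic ring is not indifferent to its substituent: 4-methoxyphenyl in place of 4-fluorophenyl gives a 7.4-fold higher number from compound 1 to compound 3 (0.87 log units; beyond the scatter) and moves the read-out toward weaker inhibition. Within the data shown here, this is the only readable comparison at this place; compound 2 has no number, and the step from compound 2 to compound 3 cannot be read. Nothing in hand bears on what lies behind the step.

Only fluoro and methoxy carry numbers here, leaving open whether a methyl, a hydroxy or an amine at this place would stand nearer compound 1 or compound 3. Also open, going by these compounds, is whether a longer alkoxy chain in place of methoxy would carry the read-out further toward weaker inhibition or bring it back.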